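Replacing the benzoxazole with a tetrazole in a thioacetamide series

The source may report more compounds than this note shows. Statements on the series, on what has been measured and on what is new or still open speak of the compounds shown alone.

Measured compounds:
Compound 1, `Cn1c(-c2ccc(NC(=O)CSc3nc4cc(Cl)ccc4o3)cc2)nc(-c2ccccc2)c1-c1ccccc1`: 42.5%
Compound 2, `Cn1c(-c2ccc(NC(=O)CSc3nc4ccccc4s3)cc2)nc(-c2ccccc2)c1-c1ccccc1`: 47.2%

In a functional assay on HT-29 cells (Homo sapiens) for cytotoxicity, read by MTT assay, with a stated time of 24 h, tested at 16 ug/mL (on this read-out lower numbers stand for a weaker effect and higher numbers for a stronger effect at the one concentration tested), compound 1 gives 42.5%, the lower of the two numbers available, with compound 2 as its nearest neighbour at 47.2%. The step of a number 4.7 percentage points higher from compound 1 to compound 2 (within the scatter) shows that exchanging one fused heteroaromatic group for another on the sulfur changed the read-out by no more than the scatter allows.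

Compound 3, `Cn1nnnc1SCC(=O)Nc1ccc(-c2nc(-c3ccccc3)c(-c3ccccc3)n2C)cc1`, has not yet been measured in this assay. It differs from compound 1 in one place: 1-methyl-1H-tetrazol-5-yl in place of 5-chloro-1,3-benzoxazol-2-yl on a sulfur. Within the data shown here, the only measured step, a number 4.7 percentage points higher from compound 1 to compound 2 (within the scatter), bears on this change only loosely, since it kept a fused two-ring group on the sulfur while compound 3 carries a single five-membered ring instead. That step gives no reason to expect a movement beyond the scatter, but the change here is larger, so the uncertainty is wider. The expected step is a number 4.5 percentage points lower from compound 1 to compound 3 (within the scatter). Compound 3 is therefore estimated at 38%, with a range from 22% to 54%.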

Compound 3, a percentage reported as activity, at one concentration (the size of the read-out at that concentration, not a potency): 72.5%
Estimate against measurement, compound 3: 34.5 percentage points below; measured number outside the range, above it.
By their numbers in this assay, from the lowest: compounds 1 and 2 (each within the scatter of the next); then compound 3.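

In this assay, the group on the sulfur proves able to move the read-out well past the scatter: the entry of 1-methyl-1H-tetrazol-5-yl gives a number 30 percentage points higher from compound 1 to compound 3 (beyond the scatter), and the same group gives a number 25.3 percentage points higher from compound 2 to compound 3 (beyond the scatter). The exchange between the two fused groups had not shown this, so the position looked indifferent until a single five-membered aromatic ring with 4 hetero atoms took the place of a fused pair of rings, and the rise appears against both fused groups, whether they carry chlorine or not. No supporting measurement is available to explain why this exchange raises the number.

The change alters several things at once, from the ring count and the heavy atoms to the number and kind of hetero atoms, and the compounds shown do not separate these, nor do they tell whether the methyl on the tetrazole contributes. As far as these compounds go, a 1-phenyl-1H-tetrazol-5-yl group, a 1-methyl-1H-imidazol-2-yl group or a plain methyl on the sulfur would each test a different part of that question, and how far the rise depends on the single concentration used remains open.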